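The source may report more compounds than this note shows. Statements on the series, on what has been measured and on what is new or still open speak of the compounds shown alone.

Measured compounds in a functional assay on MKN-74 cells (Homo sapiens) for antiproliferative activity, with a stated time of 24 h; on this read-out higher numbers stand for weaker inhibition and lower numbers for stronger inhibition:

compound 1, `NC(=O)c1c(NC(=O)c2ccccc2Cl)sc2c1CCN(Cc1cc(Cl)cc(Cl)c1)C2`: 23700 nM
compound 2, `NC(=O)c1c(NC(=O)c2ccc(C(F)(F)F)cc2)sc2c1CCN(Cc1ccc(Cl)cc1)C2`: the assay gives only a limit for compound 2, > 50000 nM
compound 3, `NC(=O)c1c(NC(=O)c2ccccc2Cl)sc2c1CCN(C(=S)Nc1cccc3ccccc13)C2`: 20700 nM

Compound 3 has the lowest of the two numbers that this assay reports, but its nearest neighbour, compound 1, lies within the scatter of it, so the two cannot be told apart on these data. The third value, that of compound 2, is a limit and not a number (the limit of > 50000 nM in this assay, at which 1 of the 3 values shown sits).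

Compound 4, `NC(=O)c1c(NC(=O)c2ccccc2Cl)sc2c1CCN(C(=S)Nc1ccccc1C(F)(F)F)C2`, keeps the core of compound 3 and differs from it in one place: 2-(trifluoromethyl)phenyl in place of naphthalen-1-yl on an amide-type nitrogen. Among the compounds with values here, no step between measured compounds covers this kind of exchange, so there is no measured size to lean on. With compound 3 and compound 1 within the scatter of each other despite their different groups on the ring nitrogen, the expectation for this step is a change no larger than the scatter, if anything towards a weaker read-out. Compound 4 is therefore expected to give about 26000 nM in this assay, with a range from 9000 nM to 75000 nM; the step from compound 3 to compound 4 is estimated as a 1.3-fold higher number from compound 3 to compound 4 (0.10 log units; within the scatter).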

Compound 4, half-maximal inhibitory concentration: 1870 nM
For compound 4 the middle estimate is 14-fold (1.14 log units) above the measured one; measured number below the stated range.
By their numbers in this assay, from the lowest: compound 4; then compounds 3 and 1 (each within the scatter of the next). At a limit, above all of these: compound 2.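

In this assay, within the data shown here, the group on the amide-type nitrogen whose other neighbour is the thiocarbonyl carbon proves able to move the read-out well beyond the scatter: exchanging naphthalen-1-yl for 2-(trifluoromethyl)phenyl gives an 11-fold lower number from compound 3 to compound 4 (1.04 log units; beyond the scatter) on an otherwise unchanged structure, and this is the first measured step. The two groups have equal heavy-atom counts and neither has hydrogen-bond donors or acceptors, so those counts do not separate them; what differs is one aromatic ring in place of two, and fluorine in place of carbon. No measured property of either group is available to bear on this step.

Open, from the compounds shown here alone, is whether the lower number follows the trifluoromethyl group itself or the single aromatic ring; a plain phenyl, a 2-chlorophenyl or a 3-(trifluoromethyl)phenyl on the same nitrogen would separate the two. Also open, going by these compounds, is whether the step holds when the 2-chlorophenyl on the other amide of the shared core gives way to another group, such as a pyridine ring.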